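Swapping the aryl group on the shared core: toward compound 4

A few compounds are considered here, and "the series" means these few. Any claim that something is new, unique, unknown or untested is made for them only; others in the source may bear on it.

Measured compounds:
- compound 1, `COc1cc(N2C(N)=C(C#N)C(c3ccc([N+](=O)[O-])cc3)C3=C2CC(C)(C)CC3=O)cc(OC)c1OC`: 70%
- compound 2, `COc1cc(N2C(N)=C(C#N)C(c3ccccc3O)C3=C2CC(C)(C)CC3=O)cc(OC)c1OC`: 2%
- compound 3, `COc1cc(N2C(N)=C(C#N)C(c3ccc(OC)c4ccccc34)C3=C2CC(C)(C)CC3=O)cc(OC)c1OC`: 40%

Of the compounds shown here, three of one series have been tested in a functional assay on Ehrlich cells (Mus musculus) for cytotoxicity, tested at 50 ug/mL (on this read-out higher numbers stand for a stronger effect at the one concentration tested and lower numbers for a weaker effect), all sharing the same core and differing only in the aryl group on a saturated ring carbon. Compound 1 gives the highest of the three numbers; its nearest neighbour is compound 3, and the furthest is compound 2, both steps lying beyond the scatter.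

Compound 4, `COc1cc(N2C(N)=C(C#N)C(c3ccc(Cl)cc3Cl)C3=C2CC(C)(C)CC3=O)cc(OC)c1OC`, is not yet measured. It differs from compound 1 in one place: 2,4-dichlorophenyl in place of 4-nitrophenyl on a saturated ring carbon.

The two measured steps from compound 1 bear on this change. Exchanging the aryl group gave a number 68 percentage points lower from compound 1 to compound 2 (beyond the scatter) and a number 30 percentage points lower from compound 1 to compound 3 (beyond the scatter); the step of a number 38 percentage points higher from compound 2 to compound 3 (beyond the scatter) shows how far these groups spread the read-out. Every change away from the 4-nitrophenyl of compound 1 so far lowered the number, so a decrease is expected for compound 4 as well, though the three data points cannot fix its size. The step is estimated as a number 25 percentage points lower from compound 1 to compound 4 (beyond the scatter), and compound 4 is expected to give 45%, within a range from 15% to 75%.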

Compound 4, a percentage reported as activity, at one concentration (the size of the read-out at that concentration, not a potency): 95%
Compound 4: the middle estimate sits 50 percentage points below what was measured; measured number above the stated range.
By their numbers in this assay, from the lowest: compound 2; then compound 3; then compound 1; then compound 4.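

In this assay the 4-nitrophenyl group of compound 1 does not mark the upper end of what this saturated ring carbon allows: the 2,4-dichlorophenyl group gives a number 25 percentage points higher from compound 1 to compound 4 (beyond the scatter) and so shows that an aryl exchange here can raise the number as well as lower it. The same exchange also gives a number 55 percentage points higher from compound 3 to compound 4 (beyond the scatter) and a number 93 percentage points higher from compound 2 to compound 4 (beyond the scatter) in the same assay, which widens the spread seen at this one position. No measurement at hand explains why the 2,4-dichlorophenyl group stands apart from the other aryl groups.

From the compounds shown here alone, whether both chlorine atoms are needed remains open, and a 4-chlorophenyl or a 2-chlorophenyl group at this carbon would address that. A read-out at one concentration also leaves the potency of compound 4 undefined.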